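The compounds below may be only part of what the source reports. "The series", "measured", "known", "first", "only" and "open" are said of these compounds alone.

Within the data shown here, compound 3 `O=C(CN1CCN(c2nnc(Cc3ccncc3)c3ccccc23)CC1)Nc1ccc(F)c(C(F)(F)F)c1` gives 16000 nM in a functional assay on A549 cells (Homo sapiens) for cytotoxicity, read by MTT assay, with a stated time of 72 h (on this read-out higher numbers stand for weaker inhibition and lower numbers for stronger inhibition), the highest of the three numbers measured so far. Compound 1 `O=C(CN1CCN(c2nnc(Cc3ccncc3)c3ccccc23)CC1)Nc1ccc(F)c(F)c1` gives 3790 nM and compound 2 `O=C(CN1CCN(c2nnc(Cc3ccncc3)c3ccccc23)CC1)Nc1ccc(Br)cc1` gives 2710 nM; the comparisons show a 4.2-fold higher number from compound 1 to compound 3 (0.63 log units; beyond the scatter) and a 5.9-fold higher number from compound 2 to compound 3 (0.77 log units; beyond the scatter). Compound 4 `O=C(CN1CCN(c2nnc(Cc3ccncc3)c3ccccc23)CC1)Nc1cc(C(F)(F)F)ccc1Cl` alters the group on the amide-type nitrogen: 2-chloro-5-(trifluoromethyl)phenyl in place of 4-fluoro-3-(trifluoromethyl)phenyl on an amide-type nitrogen. Among the measured compounds shown here, no measured step brings in a chloro or moves the trifluoromethyl, so only loose guides exist: a 4.2-fold higher number from compound 1 to compound 3 (0.63 log units; beyond the scatter) shows that introducing a trifluoromethyl raised the number modestly, while a 1.4-fold lower number from compound 1 to compound 2 (0.15 log units; within the scatter) stayed within the scatter. Since compound 4 keeps a trifluoromethyl on the phenyl, a step of a 1.1-fold lower number from compound 3 to compound 4 (0.06 log units; within the scatter) is expected in this assay, within the scatter. Compound 4 is estimated at 14000 nM, with a range from 5000 nM to 40000 nM.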

Compound 4, half-maximal inhibitory concentration: 1850 nM
Estimate against measurement, compound 4: 7.6-fold (0.88 log units) above; measured number below the stated range.
By their numbers in this assay, from the lowest: compounds 4, 2 and 1 (each within the scatter of the next, the first and the last beyond it); then compound 3.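

A trifluoromethyl on this phenyl does not by itself go with a high number in this assay, since 2-chloro-5-(trifluoromethyl)phenyl in place of 4-fluoro-3-(trifluoromethyl)phenyl gives an 8.6-fold lower number from compound 3 to compound 4 (0.94 log units; beyond the scatter) on the same amide-type nitrogen. The new group also gives a 1.5-fold lower number from compound 2 to compound 4 (0.17 log units; within the scatter) and a 2.0-fold lower number from compound 1 to compound 4 (0.31 log units; beyond the scatter), so compound 4 sits with the compounds carrying no trifluoromethyl. No measurement here accounts for the change. As far as these compounds go, the chloro and the moved trifluoromethyl enter together, so which of them matters stays open. An amine or a carboxylic acid on this phenyl also remains untested among the compounds shown.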